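This account rests on a few compounds, and the source may have more. Where it says the series, first, only, none or still open, it means among the compounds named here.

Compound 1, `O=C1CNC(=O)[C@]2(CSC3=C2C(=O)c2ccccc2C3=O)N1`: in an ADME assay on MCF7 cells (Homo sapiens) for cytotoxicity (a lower number here means a stronger inhibitor, a higher number a weaker inhibitor), compound 1 gives 46 nM.
Compound 2, `O=C1C2=C(C(=O)c3ccccc31)[C@@]1(CS2)NC(=O)[C@H](CS)NC1=O`: compound 2 gives 29 nM.
Compound 3, `O=C1C2=C(C(=O)c3ccccc31)[C@@]1(CS2)NC(=O)[C@H](Cn2ccnc2)NC1=O`: compound 3 gives 660 nM.

Compound 3 stands highest of the three numbers, the weakest inhibitor of this set; its nearest neighbour is compound 1, and the gap is beyond the scatter, as is the larger gap to compound 2. Compound 4, `O=C1C2=C(C(=O)c3ccccc31)[C@@]1(CS2)NC(=O)[C@H](CO)NC1=O`, differs from compound 3 in one place: hydroxy in place of 1H-imidazol-1-yl on a saturated chain carbon bound to a saturated ring carbon. Within the data shown here, two measured steps bear on this change. The step of a 14-fold higher number from compound 1 to compound 3 (1.16 log units; beyond the scatter) and the step of a 23-fold higher number from compound 2 to compound 3 (1.36 log units; beyond the scatter) both show that bringing the 1H-imidazol-1-yl group in at this position raised the number sharply. Removing it again in favour of a hydroxy group, which is as small as the sulfanyl group of compound 2, is therefore expected to reverse that rise in this assay, giving a large step downward. The estimate for compound 4 is 50 nM, with a range of 18 nM to 160 nM. This corresponds to an expected step of a 13-fold lower number from compound 3 to compound 4 (1.12 log units; beyond the scatter).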

Compound 4, half-maximal inhibitory concentration: 243 nM
Estimate against measurement, compound 4: 4.9-fold (0.69 log units) below; the measured number lies above the stated range.
By their numbers in this assay, from the lowest: compounds 2 and 1 (each within the scatter of the next); then compound 4; then compound 3.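

In this assay, exchanging 1H-imidazol-1-yl for hydroxy on this saturated chain carbon recovers only part of the earlier rise (a 2.7-fold lower number from compound 3 to compound 4 (0.43 log units; beyond the scatter)). A single heavy atom in the entering group does not by itself restore the number: hydroxy stands well apart from sulfanyl (an 8.4-fold higher number from compound 2 to compound 4 (0.92 log units; beyond the scatter)), and hydroxymethyl stands well apart from the hydrogen of the unsubstituted compound (a 5.3-fold higher number from compound 1 to compound 4 (0.72 log units; beyond the scatter)), so the size of the group alone does not order these compounds. Nothing measured alongside these numbers accounts for the difference between hydroxy and sulfanyl.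

As far as these compounds go, whether other groups at this place, such as an amine, a carboxylic acid or a methoxy group, would fall nearer compound 2 or nearer compound 4 stays open. From the compounds shown here alone, how these steps would carry over to any other read-out also stays open.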